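The source may report more compounds than this note shows. Statements on the series, on what has been measured and on what is new or still open speak of the compounds shown alone.

Compound 1 `COc1ccc(/C=C\c2cc(OC)c(OC)c(OC)c2)cc1OCc1ccc(CN2CC[C@H](C(=O)O)C2)cc1` slows the growth of the cells in a functional assay on B16-F10 cells (Mus musculus) for antiproliferative activity, read by CCK-8 assay, with a stated time of 48 h (a higher number here means a weaker inhibitor, a lower number a stronger inhibitor), and gives 7000 nM. Compound 2 `COc1ccc(/C=C\c2cc(OC)c(OC)c(OC)c2)cc1OCc1ccc(CN2CC[C@@H](C(=O)O)C2)cc1` has the same atoms and bonds and differs only in configuration as drawn. In this assay compound 2 gives > 10000 nM, which is a limit of the assay and not a number. The step of an at least 1.4-fold higher number from compound 1 to compound 2 (0.15 log units; that floor lies within the scatter) is therefore bounded only by the limit of > 10000 nM in this assay, at which 1 of the 2 values shown sits. Compound 3 `COc1ccc(/C=C\c2cc(OC)c(OC)c(OC)c2)cc1OCc1ccc(CN2CCCCC2C(=O)NCCN)cc1` carries 2-((2-aminoethyl)carbamoyl)piperidin-1-yl in place of 3-carboxypyrrolidin-1-yl on a saturated chain carbon bound to an aromatic carbon. Within the data shown here, no measured step covers a change of this kind, so the expectation for compound 3 stays close to where compound 2 stands. Compound 3 is expected near 10000 nM, within 3000 nM to 30000 nM. This is an expected step of a number no higher from compound 2 to compound 3 (the limit leaves the size open).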

Compound 3, half-maximal inhibitory concentration: 4600 nM
The estimate for compound 3 lay 2.2-fold (0.34 log units) above the measured number; measured number inside the range.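

In this assay, placing 2-((2-aminoethyl)carbamoyl)piperidin-1-yl on this saturated chain carbon gives an at least 2.1-fold lower number from compound 2 to compound 3 (0.33 log units; beyond the scatter), so this position tolerates a larger group than 3-carboxypyrrolidin-1-yl without loss of activity. Measured against compound 1, the same exchange gives a 1.5-fold lower number from compound 1 to compound 3 (0.18 log units; within the scatter), so from that side no real change can be claimed. The first step has only a floor, and its true size stays unknown: the limit of > 10000 nM in this assay, at which 1 of the 3 values shown sits.

The exchange alters the ring and the side chain together, so the compounds shown cannot say which of them matters. A 2-carboxypiperidin-1-yl group or a 3-aminopropyl chain on the carbamoyl nitrogen would help separate the two.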